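Amide to acid swap in an isoquinoline-free shared core series

The source may hold more compounds than are shown below. What is called first, only, known or untested is meant among the compounds shown, and "the series" means these compounds.

Measured compounds:
compound 1, `CCOc1ccccc1-c1ccc(-c2nc3cnccc3c(C[C@H](C)C(=O)O)c2C#N)cc1`, 2.2
compound 2, `CCOc1ccccc1-c1ccc(-c2nc3cnccc3c(C[C@H](C)C(N)=O)c2C#N)cc1`, 3
compound 3, `CCOc1ccccc1-c1ccc(-c2nc3cnccc3c(N[C@H](CC)C(N)=O)c2C#N)cc1`, 3

Three compounds of the shared core have been run in a physicochemical assay for lipophilicity, read by HPLC, at pH 7.5; a lower number here means a more polar compound, a higher number a more lipophilic compound. Compound 2 and compound 3 sit level at the digits read, and compound 1 lies below both. The difference between compound 2 and compound 3 is (1-carbamoylpropyl)amino in place of 2-carbamoylpropyl on an aromatic carbon; the step of no change at the digits printed from compound 2 to compound 3 (within the scatter). The difference between compound 2 and compound 1 is hydroxy in place of amino on a carbonyl carbon; the step of a number 0.80 log units lower from compound 2 to compound 1 (beyond the scatter), and the same gap shows up as a number 0.80 log units higher from compound 1 to compound 3 (beyond the scatter).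

Compound 4, `CCOc1ccccc1-c1ccc(-c2nc3cnccc3c(N[C@H](CC)C(=O)O)c2C#N)cc1`, is not yet measured. It differs from compound 3 by hydroxy in place of amino on a carbonyl carbon. The place of the change in compound 3 reads word for word the same as the place of the change from compound 2 to compound 1, so this is the same change, made once on the core of compound 2 and once on the core of compound 3.

Among the compounds with values here, because the earlier step of a number 0.80 log units lower from compound 2 to compound 1 (beyond the scatter) was the only guide, the step from compound 3 to compound 4 is expected to be a number 0.80 log units lower from compound 3 to compound 4 (beyond the scatter) in this assay. In this assay compound 4 is therefore estimated at 2.2, with the likely range running from 1.8 to 2.6. This rests on a single earlier pair; a second example does not exist among the compounds shown.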

Compound 4, distribution coefficient: 2.1
Compound 4: middle estimate off by 0.10 log units, on the high side; the range from low to high includes it.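

In this assay, hydroxy in place of amino on a carbonyl carbon gives a number 0.90 log units lower from compound 3 to compound 4 (beyond the scatter), alongside a number 0.80 log units lower from compound 2 to compound 1 (beyond the scatter) for the same change on the other core, so the step carries across these two cores with the same direction and a similar size. The change on the aromatic carbon leaves the two carboxy compounds as unseparated as the two carbamoyl compounds, at a number 0.10 log units lower from compound 1 to compound 4 (within the scatter), while the step that combines both changes reads a number 0.90 log units lower from compound 2 to compound 4 (beyond the scatter) and so tracks the carbamoyl to carboxy change. Two pairs on two closely related cores do not make a rule for other cores, and nothing measured here accounts for the size of the step.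

Still open, on these data alone, is whether the same change holds where the carbamoyl sits on a longer chain than the 1-carbamoylpropyl group, or where an ether oxygen takes the place of the amino link on the aromatic carbon. Also open, as far as these compounds go, is how a tetrazole or a methyl ester in place of the carboxy would read in this assay on either core.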